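A few compounds are considered here, and "the series" means these few. Any claim that something is new, unique, unknown or untested is made for them only; others in the source may bear on it.

Measured so far:
compound 1, `O=C1NC(=S)/C(=C/c2ccccc2Br)S1`: 3.14%
compound 2, `O=C1NC(=S)/C(=C/c2cccc(Cl)c2)S1`: -0.36%
compound 3, `O=C1NC(=S)/C(=C/c2cccc(F)c2)S1`: 0.84%

In a functional assay on HEp-2 cells (Homo sapiens) for cytotoxicity, read by MTT assay, with a stated time of 72 h, tested at 1.25 ug/mL (on this read-out lower numbers stand for less inhibition of growth and higher numbers for more inhibition of growth at the one concentration tested), compound 3 gives 0.84%, the second highest of the three numbers. Its nearest neighbour is compound 2 with -0.36%, a gap within the scatter; the furthest is compound 1 with 3.14%, also within the scatter. All three numbers therefore sit in one band near zero, and no order among them can be read from this assay.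

Compound 4, `O=C1NC(=S)/C(=C/c2cccc(Br)c2)S1`, is not yet measured. It differs from compound 3 in one place: bromo in place of fluoro on an aromatic carbon. Among the measured compounds shown here, the one measured step that bears on this change is the halogen swap at the same aromatic carbon, a number 1.2 percentage points higher from compound 2 to compound 3 (within the scatter), which stayed within the scatter. Compound 1, which also carries a bromo substituent on the ring, gives 3.14%, within the scatter of compound 3. For the measured compounds named here, nothing among the measured compounds points to a halogen swap at this carbon moving the read-out beyond the scatter. The step from compound 3 to compound 4 is thus expected to be flat, a number 0.7 percentage points higher from compound 3 to compound 4 (within the scatter). Compound 4 is expected to give 1.5% in this assay, with a range from -6% to 9%.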

Compound 4, percent growth inhibition at one concentration: -5.3%
Compound 4: middle estimate off by 6.8 percentage points, on the high side; the measured number falls inside the stated range.
By their numbers in this assay, from the lowest: compounds 4, 2, 3 and 1 (each within the scatter of the next).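

With bromo at this aromatic carbon, this assay now covers three halogens at one position, and neither new swap leaves the scatter: a number 6.1 percentage points lower from compound 3 to compound 4 (within the scatter), and a number 4.9 percentage points lower from compound 2 to compound 4 (within the scatter). The earlier compounds shown here held only the swap between fluoro and chloro, so the flat reading at this carbon now extends to bromo, and compounds 2, 3 and 4 form a single band around zero with no order among them. No measurement at hand explains where any of these numbers falls.

The compounds shown leave open whether a group other than a halogen at this aromatic carbon, such as an amine, a methoxy or a carboxylic acid, would move the read-out beyond the scatter from this band. Also open is whether the flat halogen series holds only at the single concentration tested, as the compounds shown give no reading at any other concentration and so cannot separate a true absence of effect on growth from an effect that appears only at higher exposure.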